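The compounds below may be only part of what the source reports. "The series", "measured", "known", "first", "only" and "open" are said of these compounds alone.

Measured compounds and their values:
- Compound 1, `CCNC(=O)OC[C@H]1OC(n2cnc3c(NC4CCOC4)ncnc32)[C@H](O)[C@@H]1O`, in an assay on DDT1 cells (Cricetulus griseus) for binding affinity to adenosine receptor A1 (Homo sapiens), read by radioligand binding; a higher number here means a weaker inhibitor, a lower number a stronger inhibitor: 167 nM
- Compound 2, `O=C(NC1CC1)OC[C@H]1OC(n2cnc3c(NC4CCOC4)ncnc32)[C@H](O)[C@@H]1O`, in this assay: 209 nM
- Compound 3, `O=C(NCc1ccccc1)OC[C@H]1OC(n2cnc3c(NC4CCOC4)ncnc32)[C@H](O)[C@@H]1O`, in this assay: 1830 nM

Compound 3 gives the highest number of the three, that is the weakest binding, with an 11-fold higher number from compound 1 to compound 3 (1.04 log units; beyond the scatter) and an 8.8-fold higher number from compound 2 to compound 3 (0.94 log units; beyond the scatter). The untested compound 4, `C=CCNC(=O)OC[C@H]1OC(n2cnc3c(NC4CCOC4)ncnc32)[C@H](O)[C@@H]1O`, differs from compound 3 by vinyl in place of phenyl on a saturated chain carbon bound to an amide-type nitrogen. Among the compounds with values here, the steps that bear on this are those leading into compound 3: replacing a small group on that chain carbon by phenyl raised the number markedly in this assay. Going from phenyl back to a small vinyl group is expected to reverse much of that, giving a lower number, a step of roughly a 7.3-fold lower number from compound 3 to compound 4 (0.86 log units; beyond the scatter). Compound 4 is therefore estimated at 250 nM, within a range of 110 nM to 700 nM.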

Compound 4, inhibition constant: 524 nM
For compound 4 the middle estimate is 2.1-fold (0.32 log units) below the measured one, within the range that was stated.
By their numbers in this assay, from the lowest: compounds 1 and 2 (each within the scatter of the next); then compound 4; then compound 3.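

In this assay there is a 3.5-fold lower number from compound 3 to compound 4 (0.54 log units; beyond the scatter) when vinyl replaces phenyl on the chain carbon, so losing the aromatic ring recovers only part of the ground lost. Compound 4 has no ring, yet there is still a 2.5-fold higher number from compound 2 to compound 4 (0.40 log units; beyond the scatter) and also a 3.1-fold higher number from compound 1 to compound 4 (0.50 log units; beyond the scatter) so the ring alone does not set the number here. Nothing shown explains these differences.

Going by these compounds, a propyl group, the saturated counterpart of allyl, remains open, so the share of the double bond is unknown. So does an amine or carboxylic acid on this chain.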